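A few compounds are considered here, and "the series" means these few. Any claim that something is new, unique, unknown or untested is made for them only; others in the source may bear on it.

Measured compounds:
compound 1, `COc1cc(/C=C/C(=O)c2cccc(-n3cc(-c4ccc(Cl)cc4)[nH]c3=O)c2)ccc1O`, 2970 nM
compound 2, `COc1cc(/C=C/C(=O)c2cccc(-n3cc(-c4ccccc4)[nH]c3=O)c2)cc(OC)c1OC`, 660 nM
compound 3, `COc1cc(/C=C/C(=O)c2cccc(-n3cc(-c4ccccc4)[nH]c3=O)c2)ccc1O`, 3770 nM

All three were tested in a functional assay on HT-29 cells (Homo sapiens) for inhibition; on this read-out lower numbers stand for stronger inhibition of growth and higher numbers for weaker inhibition of growth. Compound 2 gives the lowest of the three numbers, and the values of compound 1 and compound 3 both stand well above it, so compound 2 is the strongest growth inhibitor of the set measured so far.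

Compound 4, `COc1ccc(-c2cn(-c3cccc(C(=O)/C=C/c4cc(OC)c(OC)c(OC)c4)c3)c(=O)[nH]2)cc1`, has not yet been measured. It differs from compound 2 in one place: methoxy in place of hydrogen on an aromatic carbon. The same difference, cut one bond further out, reads phenyl to 4-methoxyphenyl.

Among the measured compounds shown here, only one measured step touches that ring. From compound 1 to compound 3, hydrogen replaced chloro on an aromatic carbon, and this gave a 1.3-fold higher number from compound 1 to compound 3 (0.10 log units; within the scatter). A change on this ring therefore left the read-out essentially unmoved in the single case where it was tested. For the measured compounds named here, no measured pair shows what methoxy in place of hydrogen does, so the expectation rests on that one step alone.

On that basis, no step beyond the scatter is expected in this assay for compound 4 relative to compound 2, which corresponds to an estimated 1.1-fold higher number from compound 2 to compound 4 (0.03 log units; within the scatter). The expected value for compound 4 is 700 nM, with a range from 300 nM to 1700 nM.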

Compound 4, concentration for 50% growth inhibition: 1280 nM
Estimate against measurement, compound 4: 1.8-fold (0.26 log units) below; low and high end bracket the measured number.
By their numbers in this assay, from the lowest: compounds 2 and 4 (each within the scatter of the next); then compounds 1 and 3 (each within the scatter of the next).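

In this assay, going from phenyl to 4-methoxyphenyl gives a 1.9-fold higher number from compound 2 to compound 4 (0.29 log units; within the scatter) and so shows directly that a methoxy group can sit on this aromatic carbon, para to a large group, without a step beyond the usual scatter. Among the compounds shown here, until now the only change tested on this ring was hydrogen in place of chloro, which gave a 1.3-fold higher number from compound 1 to compound 3 (0.10 log units; within the scatter) in a pair with a hydroxyl and one methoxy on the other ring; the new pair carries three methoxy groups there, so two different changes on this ring, in two different settings, have now stayed within the scatter. No outside information bears on why the read-out responds so little to these changes.

From the compounds shown here alone, the two settings have not been crossed, so it remains open whether chloro on the three-methoxy compounds, or methoxy on the hydroxyl compounds, would behave in the same way. Going by these compounds, it is also open whether this position would stay as undemanding with a very different group, such as an amine, a carboxylic acid or a longer chain like butoxy.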